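Chloro in place of fluoro: notes on compound 4

The source may report more compounds than this note shows. Statements on the series, on what has been measured and on what is new or still open speak of the compounds shown alone.

Measured in this assay:
compound 1 `N#Cc1c(-c2ccc(F)cc2)nc2c(c(-c3ccccc3)nn2-c2ccccc2)c1-c1ccc(O)cc1` — 10200 nM
compound 2 `COc1ccc(-c2c(C#N)c(-c3ccccc3)nc3c2c(-c2ccccc2)nn3-c2ccccc2)cc1OC` — > 25000 nM (a limit, not a number)
compound 3 `COc1cc(-c2c(C#N)c(-c3cccs3)nc3c2c(-c2ccccc2)nn3-c2ccccc2)ccc1O` — 15400 nM

In a functional assay on K562 cells (Homo sapiens) for antiproliferative activity, read by resazurin assay, with a stated time of 72 h (a lower number here means a stronger inhibitor, a higher number a weaker inhibitor), compound 1 gives 10200 nM, the lower of the two numbers reported. Compound 3 gives 15400 nM, and the gap between the two lies within the scatter, so no order between them is claimed. Compound 2 returns only a limit, > 25000 nM, and this is the limit of > 25000 nM in this assay, at which 1 of the 3 values shown sits.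

Compound 4 `N#Cc1c(-c2ccc(Cl)cc2)nc2c(c(-c3ccccc3)nn2-c2ccccc2)c1-c1ccc(O)cc1` is not yet measured in this assay. It differs from compound 1 by chloro in place of fluoro on an aromatic carbon. Among the compounds with values here, no pair of measured compounds isolates this change, so nothing sizes it. The expected step is one within the scatter and without clear direction, so that the estimated change reads a 1.2-fold lower number from compound 1 to compound 4 (0.08 log units; within the scatter). Compound 4 is accordingly expected near 8500 nM, within a range from 3500 nM to 25000 nM.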

Compound 4, half-maximal inhibitory concentration: 20800 nM
Compound 4: middle estimate off by 2.4-fold (0.39 log units), on the low side; the range from low to high includes it.
By their numbers in this assay, from the lowest: compounds 1, 3 and 4 (each within the scatter of the next, the first and the last beyond it). At a limit, above all of these: compound 2.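

The 4-fluorophenyl to 4-chlorophenyl exchange gives the series its first reading of a single change. In this assay the exchange reads a 2.0-fold higher number from compound 1 to compound 4 (0.31 log units; beyond the scatter) and counts as a modest step. The position, on a six-membered aromatic ring of carbon only and para to a large group, is therefore not indifferent to this swap of one halogen for another, although nothing at hand accounts for the size or direction of the step.

As far as these compounds go, what an amine or a carboxylic acid would do at this position remains open, and one step cannot show a trend across substituents. Compound 1 and compound 3 differ in more than one place, so their values size no single change in the rest of the molecule.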